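This account rests on a few compounds, and the source may have more. Where it says the series, first, only, none or still open, it means among the compounds named here.

Two compounds share one core and differ only in the group carried on the six-membered aromatic ring with one nitrogen. Compound 1 `CCCn1ccc2cc(OCCCc3cccnc3)cc(Cl)c2c1=O` gives 631 nM in a functional assay on CHO cells for agonist activity at metabotropic glutamate receptor 2 (Homo sapiens), read by GTPgammaS binding; a higher number here means that more compound is needed for the effect, a lower number that less compound is needed. Compound 2 `CCCn1ccc2cc(-c3ccc(N(C)C)nc3)cc(Cl)c2c1=O` gives 5010 nM in this assay, the higher of the two numbers, and its gap to compound 1 lies beyond the scatter. Compound 3 `CCCn1ccc2cc(-c3ccc(OCCc4ccccc4)nc3)cc(Cl)c2c1=O` differs from compound 2 in one place: phenethyloxy in place of dimethylamino on an aromatic carbon. Going by the values given here, no step between two measured compounds corresponds to this change, so any expectation rests only on what compound 1 and compound 2 show. A step toward lower numbers, beyond the scatter, is expected, estimated as a 4.6-fold lower number from compound 2 to compound 3 (0.66 log units; beyond the scatter), because compound 1 gives 631 nM while compound 2 gives 5010 nM in this assay. For compound 3 the expected value in this assay is 1100 nM, with a range from 300 nM to 4000 nM.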

Compound 3, half-maximal effective concentration: 631 nM
Compound 3: the middle estimate sits 1.7-fold (0.24 log units) above what was measured; measured number inside the range.
By their numbers in this assay, from the lowest: compounds 1 and 3 (each within the scatter of the next); then compound 2.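

In this assay, going by these compounds alone, phenethyloxy in place of dimethylamino on the aromatic carbon next to the ring nitrogen brings a 7.9-fold lower number from compound 2 to compound 3 (0.90 log units; beyond the scatter) and gives the first direct reading of a change at this position. The step shows that the number responds to the group at this place, and that a larger group with a six-membered aromatic ring of carbon only is compatible with a lower number than dimethylamino gives. This holds for this one pair on the shared core and does not establish a trend across groups.

The compounds shown leave open which part of phenethyloxy goes with the step: the oxygen, the chain or the aromatic ring. Methoxy, benzyloxy or a piperidine at the same place would bear on that question. No measurement here offers an explanation for the step.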